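Substituent change on the phenyl of compound 1 and cytotoxicity

The source may report more compounds than this note shows. Statements on the series, on what has been measured and on what is new or still open speak of the compounds shown alone.

Measured compounds:
compound 1 `COc1nc2ccc(Br)cc2cc1C(c1ccccc1)n1cc(-c2ccccc2)nn1`: 13.9%
compound 2 `CCCCCCCCc1cn(C(c2ccccc2)c2cc3cc(Br)ccc3nc2OC)nn1`: 0.1%
compound 3 `CCCCCc1cn(C(c2ccccc2)c2cc3cc(Br)ccc3nc2OC)nn1`: -9.81%

In an ADME assay on HeLa cells (Homo sapiens) for cytotoxicity, read by sulforhodamine B assay, with a stated time of 48 h, tested at 10 uM (on this read-out higher numbers stand for more inhibition at the one concentration tested (going by the name of the read-out) and lower numbers for less inhibition), compound 1 stands highest of the three numbers. The nearest is compound 2: a number 13.8 percentage points lower from compound 1 to compound 2 (beyond the scatter). The furthest is compound 3: a number 23.7 percentage points lower from compound 1 to compound 3 (beyond the scatter). Between those two, a number 9.9 percentage points lower from compound 2 to compound 3 (within the scatter).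

Compound 4 `COc1nc2ccc(Br)cc2cc1C(c1ccccc1)n1cc(-c2ccccc2C(F)(F)F)nn1` differs from compound 1 by trifluoromethyl in place of hydrogen on an aromatic carbon. Going by the values given here, none of the measured steps bears directly on this change: each exchanges phenyl for an alkyl chain or shortens that chain, and none adds a group to a phenyl that remains. Going by the only measured steps, no step beyond the scatter is therefore expected in this assay. For compound 4 the estimate is 14%, within 0% to 30%. The expected step from compound 1 is a number 0.1 percentage points higher from compound 1 to compound 4 (within the scatter).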

Compound 4, a percentage reported as inhibition, at one concentration (the size of the read-out at that concentration, not a potency): -1.3%
Compound 4: the middle estimate sits 15.3 percentage points above what was measured, and the stated range ends above it.
By their numbers in this assay, from the lowest: compounds 3, 4 and 2 (each within the scatter of the next); then compound 1.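

In this assay the phenyl itself proves sensitive to substitution, with trifluoromethyl ortho to a large group giving a number 15.2 percentage points lower from compound 1 to compound 4 (beyond the scatter) even though the phenyl stays. Compound 4 falls in with the chain compounds, with a number 8.5 percentage points higher from compound 3 to compound 4 (within the scatter) and a number 1.4 percentage points lower from compound 2 to compound 4 (within the scatter) in the two comparisons, so among these four only the unsubstituted phenyl of compound 1 stands apart. Nothing available explains this result.

Open, from the compounds shown here alone, is whether a smaller group such as fluorine or methoxy at this place reads the same as trifluoromethyl. Also open, going by these compounds, is whether trifluoromethyl or an amine on another carbon of the phenyl keeps the number of compound 1.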